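The compounds below may be only part of what the source reports. "The series", "measured", "known", "first", "only" and "open" are said of these compounds alone.

Measured compounds: compound 1 `COc1ccc(-c2csc(NC(=O)COc3ccc(C(=O)c4ccccc4)cc3C)n2)cc1` gives 28400 nM in a functional assay on Ehrlich cells (Mus musculus) for cytotoxicity, read by MTT assay, with a stated time of 48 h; on this read-out higher numbers stand for weaker inhibition and lower numbers for stronger inhibition; compound 2 `COc1ccc(-c2csc(NC(=O)COc3ccc(C(=O)c4ccc(F)cc4)cc3C)n2)cc1` gives 5400 nM; compound 3 `Cc1cc(C(=O)c2cccc(Br)c2)ccc1OCC(=O)Nc1nc(-c2ccccc2)cs1` gives 24400 nM.

Compound 3 stands second highest of the three numbers, though its gap to compound 1 lies within the scatter, while compound 2 sits beyond the scatter below it. Compound 4 `COc1ccc(-c2csc(NC(=O)COc3ccc(C(=O)c4cccc(Br)c4)cc3C)n2)cc1` differs from compound 3 by methoxy in place of hydrogen on an aromatic carbon. Within the data shown here, the single measured step, a 5.3-fold lower number from compound 1 to compound 2 (0.72 log units; beyond the scatter), concerns a fluoro on a different ring and does not bear directly on this change; compounds 1 and 2 already carry the methoxy, and their two numbers give no single level for it. The step is therefore expected to be a 1.2-fold lower number from compound 3 to compound 4 (0.09 log units; within the scatter), nothing beyond the scatter. Compound 4 is expected to give 20000 nM, within 7000 nM to 60000 nM.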

Compound 4, half-maximal inhibitory concentration: 39200 nM
Estimate against measurement, compound 4: 2.0-fold (0.29 log units) below; the range from low to high includes it.
By their numbers in this assay, from the lowest: compound 2; then compounds 3, 1 and 4 (each within the scatter of the next).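

In this assay, methoxy in place of hydrogen on the aromatic carbon para to a large group gives a 1.6-fold higher number from compound 3 to compound 4 (0.21 log units; within the scatter) and so leaves no readable shift with the 3-bromophenyl ketone. With the methoxy present, bromo in place of hydrogen gives a 1.4-fold higher number from compound 1 to compound 4 (0.14 log units; within the scatter) as well, while 3-bromophenyl in place of 4-fluorophenyl gives a 7.3-fold higher number from compound 2 to compound 4 (0.86 log units; beyond the scatter) and sets compound 2 apart. Nothing available explains these numbers.

On these data alone, whether an amine or a carboxylic acid at this position would move the number remains open. So does whether the methoxy step holds with the 4-fluorophenyl ketone.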